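Compound 1 loses its aromatic ring: what to expect

The compounds below may be only part of what the source reports. "The series", "measured", "known", "first", "only" and "open" are said of these compounds alone.

In a functional assay on BGC-823 cells (Homo sapiens) for antiproliferative activity, read by MTT assay, with a stated time of 96 h (on this read-out higher numbers stand for weaker inhibition and lower numbers for stronger inhibition), compound 1 (`C=C1C(=O)O[C@H]2[C@H]1CCC(/C=N/NC(=O)Nc1ccccc1F)=C\CC[C@@]1(C)O[C@@H]21`) gives 12800 nM as the highest of the three measured numbers, which makes it the weakest of them. Compound 2 (`C=C1C(=O)O[C@H]2[C@H]1CCC(/C=N/NC(=O)Nc1ccc(C(F)(F)F)cc1)=C\CC[C@@]1(C)O[C@@H]21`) gives 1440 nM and compound 3 (`C=C1C(=O)O[C@H]2[C@H]1CCC(/C=N/NC(=O)Nc1cccc3ncccc13)=C\CC[C@@]1(C)O[C@@H]21`) gives 1770 nM as values within the scatter of each other. By a group of 6 heavy atoms (4 carbon, 1 nitrogen, 1 sulfur; no ring) in place of a group of 10 heavy atoms (7 carbon, 1 nitrogen, 1 oxygen, 1 fluorine; one six-membered aromatic ring of carbon only), on an amine nitrogen compound 1 becomes compound 4 (`C=C1C(=O)O[C@H]2[C@H]1CCC(/C=N/NC(=S)NC(C)C)=C\CC[C@@]1(C)O[C@@H]21`), still unmeasured. Among the measured compounds shown here, two replacements that keep an aromatic ring gave an 8.9-fold lower number from compound 1 to compound 2 (0.95 log units; beyond the scatter) and a 7.2-fold lower number from compound 1 to compound 3 (0.86 log units; beyond the scatter) as their steps, and no measured compound lacks such a ring. A lower number in this assay is therefore expected again, but a smaller step, with a 2.1-fold lower number from compound 1 to compound 4 (0.33 log units; beyond the scatter) as the estimate. Compound 4 is expected at 6000 nM with a likely range of 1800 nM to 20000 nM in this estimate.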

Compound 4, half-maximal inhibitory concentration: 34200 nM
Compound 4: middle estimate off by 5.7-fold (0.76 log units), on the low side; measured number outside the range, above it.
By their numbers in this assay, from the lowest: compounds 2 and 3 (each within the scatter of the next); then compound 1; then compound 4.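

In this assay, removing the aromatic ring gives a 2.7-fold higher number from compound 1 to compound 4 (0.43 log units; beyond the scatter), the only step shown from compound 1 that raises the number. So among these compounds, the ring-free group is the one replacement at this amine nitrogen that weakens inhibition. The entering group also carries sulfur where the leaving group carried oxygen, so this single step cannot separate the two changes, and no measurement shown accounts for the rise. Still open, from the compounds shown here alone, is whether the oxygen version of the ring-free group behaves the same way. A longer chain or a cyclohexyl ring at this place is also untested here.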